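Sulfur substituent exchange on the shared core

The source may report more compounds than this note shows. Statements on the series, on what has been measured and on what is new or still open speak of the compounds shown alone.

In a functional assay on HT cells (Homo sapiens) for antiproliferative activity, read by fluorescence, with a stated time of 72 h (a higher number here means a weaker inhibitor of growth, a lower number a stronger inhibitor of growth), compound 2 `CC(C)c1n[nH]c2c(NCc3ccc(-c4ccccn4)cc3)nc(SC3CCCC3O)nc12` gives 567 nM, the lower of the two numbers shown, though the gap to compound 1 `CSc1nc(NCc2ccc(-c3ccccn3)cc2)c2[nH]nc(C(C)C)c2n1`, which gives 783 nM, is within the scatter: a 1.4-fold lower number from compound 1 to compound 2 (0.14 log units; within the scatter). Compound 3 `CC(C)c1n[nH]c2c(NCc3ccc(-c4ccccn4)cc3)nc(SC3CCCCC3N)nc12` differs from compound 2 by 2-aminocyclohexyl in place of 2-hydroxycyclopentyl on a sulfur. Among the compounds with values here, the single measured step concerns a different exchange on the same sulfur and was itself within the scatter, so no measured step bears directly on this change; no movement beyond the scatter is expected in this assay. Compound 3 is therefore estimated at 500 nM, range 200 nM to 1300 nM. The expected step is a 1.1-fold lower number from compound 2 to compound 3 (0.05 log units; within the scatter).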

Compound 3, concentration for 50% growth inhibition: 139 nM
Beside the measured number, compound 3's estimate is 3.6-fold (0.56 log units) above it, outside the stated range (below it).
By their numbers in this assay, from the lowest: compound 3; then compounds 2 and 1 (each within the scatter of the next).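

The position on sulfur is not indifferent in this assay: there is a 4.1-fold lower number from compound 2 to compound 3 (0.61 log units; beyond the scatter), and a 5.6-fold lower number from compound 1 to compound 3 (0.75 log units; beyond the scatter), whereas the earlier exchange at this sulfur stayed within the scatter. Compound 3 therefore stands apart from both earlier compounds, and 2-aminocyclohexyl is the only substituent shown that separates from the others. Nothing available explains this difference.

The change alters ring size and replaces the hydroxy group with an amino group at once, so the two contributions remain unseparated. 2-Aminocyclopentyl or 2-hydroxycyclohexyl on the same sulfur would divide them.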